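Swapping azido for sulfanyl on a deoxyribose nucleoside

The source may report more compounds than this note shows. Statements on the series, on what has been measured and on what is new or still open speak of the compounds shown alone.

The study concerns three measured nucleosides and one unmeasured relative. Compound 1 `[N-]=[N+]=Nc1nccc2c1ncn2[C@H]1C[C@H](O)[C@@H](CO)O1` carries an azido group on its aromatic core and a deoxyribose sugar. In a functional assay (Homo sapiens) for inhibition of Nucleic Acid, tested at 100 uM (on this read-out lower numbers stand for less inhibition and higher numbers for more inhibition at the one concentration tested (going by the name of the read-out)), compound 1 gives 4%. Compound 2 `[N-]=[N+]=Nc1nccc2c1ncn2C1O[C@H](CO)[C@@H](O)[C@H]1O` has the same azido core on a ribose sugar, and in this assay compound 2 gives 4%. Compound 3 `OC[C@H]1OC(n2cnc3c(S)nccc32)[C@H](O)[C@@H]1O` pairs the ribose sugar with a sulfanyl group instead, and in this assay compound 3 gives 6%. Compound 1 thus sits level with compound 2 at the digits shown, the two together forming the lowest of the three numbers, with compound 3 differing only within the scatter.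

Compound 4 `OC[C@H]1O[C@@H](n2cnc3c(S)nccc32)C[C@@H]1O` is the sulfanyl counterpart of compound 1 on the deoxyribose sugar. The change is sulfanyl in place of azido on an aromatic carbon. Among the measured compounds shown here, the one measured step of this kind, a number 2 percentage points higher from compound 2 to compound 3 (within the scatter), ran on the ribose sugar and stayed within the scatter. By analogy, no change beyond the scatter is expected for compound 4, with a step of a number 2 percentage points higher from compound 1 to compound 4 (within the scatter). The estimate for compound 4 is therefore 6%, within a range of -4% to 16%.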

Compound 4, a percentage reported as inhibition, at one concentration (the size of the read-out at that concentration, not a potency): 10%
Estimate against measurement, compound 4: 4 percentage points below; measured number inside the range.
By their numbers in this assay, from the lowest: compounds 1, 2, 3 and 4 (each within the scatter of the next).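

The change of sulfanyl in place of azido on an aromatic carbon, next to the ring nitrogen, can now be read on the deoxyribose sugar as well as on ribose. In this assay the step is a number 6 percentage points higher from compound 1 to compound 4 (within the scatter), so on this sugar too the swap does not shift the number beyond the scatter. The two readings of the change agree, which suggests that the sugar does not alter the outcome of this swap in these compounds: the same change on two cores in this assay, a number 2 percentage points higher (within the scatter) from compound 2 to compound 3 and a number 6 percentage points higher (within the scatter) from compound 1 to compound 4, 4 percentage points apart, within the scatter of two such steps

Each of the four compounds lies within the scatter of the next, so they do not show whether any group at this position can change the read-out at all. On these data alone, whether an amine or a methoxy group here, on either sugar, would give a step beyond the scatter remains open.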